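A Methoxyphenyl in Place of a Dichlorophenyl

The compounds below may be only part of what the source reports. "The series", "measured", "known", "first", "only" and "open" are said of these compounds alone.

Of the compounds shown here, two have been measured so far. Compound 1 `COc1cccc(-c2cc(C(=O)Nc3ccc(Oc4ccnc5cc(OCCCN6CCCCC6)c(OC)cc45)c(F)c3)c3ccccc3n2)c1` gives 210 nM in a functional assay on NCI-H460 cells (Homo sapiens) for cytotoxicity, read by MTT assay, with a stated time of 72 h; a higher number here means a weaker inhibitor, a lower number a stronger inhibitor. Compound 2 `COc1cc2c(Oc3ccc(NC(=O)c4cc(-c5ccc(Cl)c(Cl)c5)nc5ccccc45)cc3F)ccnc2cc1OCCCN1CCCC1` gives 400 nM in this assay; this is the higher of the two numbers, but the gap to compound 1 lies within the scatter, so the two cannot be told apart on these data.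

Compound 3 `COc1cccc(-c2cc(C(=O)Nc3ccc(Oc4ccnc5cc(OCCCN6CCCC6)c(OC)cc45)c(F)c3)c3ccccc3n2)c1` is not yet measured. It differs from compound 2 in one place: 3-methoxyphenyl in place of 3,4-dichlorophenyl on an aromatic carbon. The rest of the shared core is unchanged. Compound 3 carries the same 3-methoxyphenyl group as compound 1, though the two differ elsewhere, so the value of compound 1 is only a loose guide.

Among the compounds with values here, no measured pair differing in this single place exists, so the size of the step cannot be read off. Compound 1 and compound 2 sit within the scatter of each other, which suggests a modest change at most. The expected step of a 1.5-fold lower number from compound 2 to compound 3 (0.19 log units; within the scatter) is small, leaning toward a slightly lower number. Compound 3 is estimated to give 260 nM in this assay, with a range from 120 nM to 550 nM.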

Compound 3, half-maximal inhibitory concentration: 290 nM
For compound 3 the middle estimate is 1.1-fold (0.05 log units) below the measured one; low and high end bracket the measured number.
By their numbers in this assay, from the lowest: compounds 1, 3 and 2 (each within the scatter of the next).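

In this assay, putting 3-methoxyphenyl in place of 3,4-dichlorophenyl on the aromatic carbon next to the ring nitrogen gives a 1.4-fold lower number from compound 2 to compound 3 (0.14 log units; within the scatter), so this position can carry either group with no difference that these data can resolve, although the entering group has one hydrogen-bond acceptor and the leaving group none. Within the data shown here, compound 3 also gives the first view of a change at the far end of the chain, because compound 1 and compound 2 differ in two places and could not be compared directly: pyrrolidin-1-yl in place of piperidin-1-yl gives a 1.4-fold higher number from compound 1 to compound 3 (0.14 log units; within the scatter), so this swap cannot be resolved either. Nothing at hand bears on why either swap gives the result it does.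

The compounds shown leave open how this assay responds to a phenyl ring bearing an amine or a carboxylic acid at the same aromatic carbon, or to a morpholin-4-yl group in place of pyrrolidin-1-yl on the chain. On these data alone, since both steps lie within the scatter, it also remains open whether any change at these two places can move the number by more than repeat measurements vary.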